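This account rests on a few compounds, and the source may have more. Where it says the series, first, only, none or still open, it means among the compounds named here.

Compound 1, `CC[C@@H](C)[C@H](N)CN(C(=O)[C@@H]1C[C@H]1c1ccccc1)c1ccc(-c2ccccc2)cc1`, and compound 2, `CC(C)[C@H](N)CN(C(=O)[C@@H]1C[C@H]1c1ccccc1)c1ccc(-c2ccccc2)cc1`, share one core and differ only on the chain that carries the amine. In a functional assay for agonist activity at G protein-coupled receptor 88 (Homo sapiens), read by HTRF and cAMP accumulation (a higher number here means that more compound is needed for the effect, a lower number that less compound is needed), compound 1 gives 1.4 nM, while compound 2 gives 1.1 nM; the change amounts to a 1.3-fold lower number from compound 1 to compound 2 (0.10 log units; within the scatter), so the two compounds cannot be told apart on these numbers. Compound 2 therefore stands alongside compound 1 rather than ahead of it. Compound 3, `CC(C)(N)CN(C(=O)[C@@H]1C[C@H]1c1ccccc1)c1ccc(-c2ccccc2)cc1`, carries 1-amino-1-methylethyl in place of 1-amino-2-methylpropyl on a saturated chain carbon bound to an amide-type nitrogen. Within the data shown here, the one measured step that bears on this, from compound 1 to compound 2, also trimmed this chain and stayed within the scatter, but it did not alter the carbon that bears the amine, as the present change does. Among the measured compounds shown here, no measured pair speaks to that, so the expected step of a 2.7-fold higher number from compound 2 to compound 3 (0.44 log units; beyond the scatter) is taken as small to moderate, tending toward a higher number. Compound 3 is therefore estimated at 3 nM in this assay, with a range of 0.8 nM to 12 nM.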

Compound 3, half-maximal effective concentration: 1.4 nM
Estimate against measurement, compound 3: 2.1-fold (0.33 log units) above; the measured number falls inside the stated range.
By their numbers in this assay, from the lowest: compounds 2, 1 and 3 (each within the scatter of the next).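

Replacing 1-amino-2-methylpropyl with 1-amino-1-methylethyl on a saturated chain carbon bound to an amide-type nitrogen alters the carbon that bears the amine, and the entering group has no defined stereocentre. Even so, this assay gives a 1.3-fold higher number from compound 2 to compound 3 (0.10 log units; within the scatter) and no change at the digits printed from compound 1 to compound 3 (within the scatter), so the three compounds cannot be told apart, and among them the defined stereocentre of the leaving group is not needed for a number of this size. Nothing available explains why this change leaves the number within the scatter.

As far as these compounds go, whether the number would hold with a hydroxyl or a carboxylic acid in place of the amine remains open. So does the outcome with a longer chain, such as 1-aminopentyl, or with the opposite configuration at the amine-bearing carbon of compound 2.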